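An Acetyl Group Replaces a Nitrogen Hydrogen: Expected Cytotoxicity

The compounds below may be only part of what the source reports. "The series", "measured", "known", "first", "only" and "open" are said of these compounds alone.

Two close relatives, compound 1 `O=[N+]([O-])c1ccc(/N=N/Nc2ccc([N+](=O)[O-])cc2Br)c(Br)c1` and compound 2 `O=[N+]([O-])c1ccc(/N=N/Nc2ccc([N+](=O)[O-])cc2F)c(F)c1`, have been tested in a functional assay on HeLa cells (Homo sapiens) for cytotoxicity, read by MTT assay, with a stated time of 72 h; on this read-out higher numbers stand for weaker inhibition and lower numbers for stronger inhibition. In this assay compound 1 gives 940 nM, while compound 2 gives 3300 nM. Compound 2 therefore stands at the higher of the two numbers, and the gap between compound 2 and compound 1 lies beyond the scatter, so compound 2 is the weaker inhibitor of the pair.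

The next compound, compound 3 `CC(=O)N(/N=N/c1ccc([N+](=O)[O-])cc1F)c1ccc([N+](=O)[O-])cc1F`, keeps the whole skeleton of compound 2 and changes one point: acetyl in place of hydrogen on a nitrogen on an aromatic ring. The new compound thus carries an acetyl group where compound 2 carried a bare hydrogen.

Among the compounds with values here, no measured pair in this small set shows what such an exchange does, so the expectation rests only on the starting value of compound 2, 3300 nM, and on the small size of the change. The step of a 1.5-fold higher number from compound 2 to compound 3 (0.18 log units; within the scatter) is expected to be modest and, if anything, toward a higher number. Compound 3 is therefore estimated at 5000 nM, with a plausible range from 1500 nM to 20000 nM.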

Compound 3, half-maximal inhibitory concentration: 4760 nM
For compound 3 the middle estimate is 1.1-fold (0.02 log units) above the measured one; measured number inside the range.
By their numbers in this assay, from the lowest: compound 1; then compounds 2 and 3 (each within the scatter of the next).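

Within the data shown here, this is the first pair in the set that differs in one place, and it puts a number on the exchange at this nitrogen: acetyl in place of hydrogen gives a 1.4-fold higher number from compound 2 to compound 3 (0.16 log units; within the scatter) in this assay. The hydrogen on this nitrogen can therefore leave and acetyl, with its 3 heavy atoms and a carbonyl, can enter without a change that can be told from the ordinary spread of repeated measurements, so this bare hydrogen is not needed to keep the cytotoxicity seen with compound 2 on these cells. Nothing measured here offers an explanation for this result.

The compounds shown leave open how far this tolerance extends, for instance whether a methyl group, which has no carbonyl, or a longer chain or a benzoyl group would give a similar number on the same nitrogen. They also leave open whether the same exchange on compound 1, which carries bromine where compound 2 carries fluorine, would likewise stay within the scatter.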